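The source may hold more compounds than are shown below. What is called first, only, known or untested is meant among the compounds shown, and "the series" means these compounds.

Compound 1 `CN(C)c1ncc(C(=O)Nc2ccccn2)nc1Cl`: 158 nM
Compound 2 `Nc1ncc(Cl)nc1C(=O)Nc1ccccn1`: 11 nM
Compound 3 `O=C(Nc1ccccn1)c1cncc(Cl)n1`: 254 nM

These three compounds were tested in an assay on Ltk cells for inhibition of metabotropic glutamate receptor 5 (Homo sapiens), read by fluorescence; a lower number here means a stronger inhibitor, a higher number a weaker inhibitor. Compound 3 gives the highest number of the three: compound 1 sits close to it, the step of a 1.6-fold higher number from compound 1 to compound 3 (0.21 log units; within the scatter), while compound 2 lies far away, the step of a 23-fold higher number from compound 2 to compound 3 (1.36 log units; beyond the scatter).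

Compound 4 `CNc1ncc(Cl)nc1C(=O)Nc1ccccn1` is not yet measured. It differs from compound 3 in one place: methylamino in place of hydrogen on an aromatic carbon. For the measured compounds named here, two measured steps bear on this. Putting a dimethylamino group at this position, as in compound 1, changed little, whereas an amino group at this position, as in compound 2, gave a much lower number. A methylamino group stands between these two, carrying one hydrogen-bond donor where the amino group carries two and the dimethylamino none. The expected step in this assay from compound 3 to compound 4 is therefore a clear drop in the number, a 6.4-fold lower number from compound 3 to compound 4 (0.80 log units; beyond the scatter), though probably smaller than that seen for compound 2. Compound 4 is estimated at 40 nM, with a range from 12 nM to 150 nM.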

Compound 4, half-maximal inhibitory concentration: 145 nM
Estimate against measurement, compound 4: 3.6-fold (0.56 log units) below, and the stated range covers the measured number.
By their numbers in this assay, from the lowest: compound 2; then compounds 4, 1 and 3 (each within the scatter of the next).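

In this assay, one methyl on the nitrogen is enough to undo most of the gain seen with the amino group: the change from amino to methylamino gives a 13-fold higher number from compound 2 to compound 4 (1.12 log units; beyond the scatter). Measured against the compound with hydrogen at this position, methylamino gives only a 1.8-fold lower number from compound 3 to compound 4 (0.24 log units; within the scatter). The large gain therefore belongs to the amino group of compound 2 alone among the groups shown, since neither methylamino nor dimethylamino moves the number beyond the scatter from compound 3.

No measurement among these compounds explains why a single methyl has so large an effect. On these data alone, it also remains open whether another small group at this position, such as hydroxyl or methoxy, could match the amino group of compound 2.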